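Inverting one ring stereocentre of compound 2

This account rests on a few compounds, and the source may have more. Where it says the series, first, only, none or still open, it means among the compounds named here.

In a functional assay on QGY cells (Homo sapiens) for cytotoxicity, read by MTT assay, with a stated time of 48 h (a higher number here means a weaker inhibitor, a lower number a stronger inhibitor), compound 2 `COc1cc([C@H]2C[C@]2(CO)C(=O)Nc2ccccc2)cc(OC)c1OC` gives > 100000 nM. This is a limit of the assay and not a number, so compound 2 has no exact position in the series.

Within the data shown here, compound 1 `COc1cc([C@@H]2C[C@]2(CO)C(=O)NCc2ccc(C)cc2)cc(OC)c1OC` gives 25100 nM, the only exact value so far.

Compound 3 `COc1cc([C@@H]2C[C@]2(CO)C(=O)Nc2ccccc2)cc(OC)c1OC` is related to compound 2 by the two compounds have the same atoms and bonds and differ only in configuration as drawn: 1 of 2 stereo elements differ; a stereocentre at a saturated ring carbon is drawn R in compound 2 and S in compound 3. A stereocentre at a saturated ring carbon is drawn R in compound 2 and S in compound 3, while the atoms and bonds stay the same.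

Among the measured compounds shown here, no measured step in this assay covers this kind of change, so the size of the step is a judgement. A moderate gain in strength is expected, seen in an at least 1.6-fold lower number from compound 2 to compound 3 (0.22 log units; that floor lies within the scatter), and a second result at the limit remains possible. The expectation is anchored on compound 1 at 25100 nM.

For compound 3, the estimated value is 60000 nM, with an expected range of 20000 nM to 150000 nM.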

Compound 3, half-maximal inhibitory concentration: 51300 nM
Compound 3: middle estimate off by 1.2-fold (0.07 log units), on the high side; low and high end bracket the measured number.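

In this assay the series now shows an at least 1.9-fold lower number from compound 2 to compound 3 (0.28 log units; that floor lies within the scatter), and this step can be set on the ring stereocentre alone, because of one fact: the fact that compounds 2 and 3 differ only in the configuration as drawn

The step is only a floor and its true size stays unknown, because compound 2 carries a limit and not a number: the limit of > 100000 nM in this assay, at which 1 of the 3 values shown sits.

Among these compounds, with the ring configuration kept, phenyl in place of 4-methylbenzyl on the amide-type nitrogen gives a 2.0-fold higher number from compound 1 to compound 3 (0.31 log units; beyond the scatter), the first exact step.

As far as these compounds go, whether the same inversion has a comparable effect with 4-methylbenzyl on that nitrogen stays open, as does the role of the other stereocentre. Also open, from the compounds shown here alone, is how an unsubstituted benzyl, or a longer chain ending in an amine or a carboxylic acid, would read at that nitrogen.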